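The source may hold more compounds than are shown below. What is called first, only, known or untested is meant among the compounds shown, and "the series" means these compounds.

Measured compounds in a functional assay on Caco-2 cells (Homo sapiens) for cytotoxicity, with a stated time of 48 h; on this read-out higher numbers stand for weaker inhibition and lower numbers for stronger inhibition:
- compound 1 `COc1cccc(/C=C/C(=O)c2c(OC)cc(OC)cc2OC)c1` gives 3900 nM
- compound 2 `COc1cc(OC)c(C(=O)/C=C/c2ccc(Br)cc2)c(OC)c1` gives 6800 nM
- compound 3 `COc1cc(OC)c(C(=O)/C=C/c2ccccc2SC)c(OC)c1` gives 8800 nM

Compound 2 stands second highest of the three numbers, nearest to compound 3 and furthest from compound 1, and both of its neighbours lie within the scatter of it: the step of a 1.7-fold higher number from compound 1 to compound 2 (0.24 log units; within the scatter) is within the scatter, as is a 1.3-fold higher number from compound 2 to compound 3 (0.11 log units; within the scatter). Only a 2.3-fold higher number from compound 1 to compound 3 (0.35 log units; beyond the scatter) goes beyond the scatter, and then only modestly. Across the three compounds the shared core is kept and only the aryl ring on the double-bonded chain carbon is exchanged, with little effect on the read-out.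

Compound 4 `COc1cc(OC)c(C(=O)/C=C/c2ccc([N+](=O)[O-])cc2)c(OC)c1` differs from compound 2 by nitro in place of bromo on an aromatic carbon. Within the data shown here, no measured step introduces a nitro, so the bearing of the measured steps is indirect: each of them is an exchange on the same aryl ring, and all three are within the scatter or only modestly beyond it. On that basis the step into compound 4 in this assay is expected to stay within the scatter, with no direction favoured.

Compound 4 is therefore estimated at 7000 nM, with a range from 3500 nM to 14000 nM. The expected step of a 1.0-fold higher number from compound 2 to compound 4 (0.01 log units; within the scatter) lies within the scatter.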

Compound 4, half-maximal inhibitory concentration: 2600 nM
Compound 4: middle estimate off by 2.7-fold (0.43 log units), on the high side; measured number below the stated range.
By their numbers in this assay, from the lowest: compounds 4, 1, 2 and 3 (each within the scatter of the next, the first and the last beyond it).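

In this assay, among these compounds, the exchange of bromo for nitro on an aromatic carbon, para to a large group, gives a 2.6-fold lower number from compound 2 to compound 4 (0.42 log units; beyond the scatter) and is the first exchange on this aryl ring to pass beyond the scatter towards stronger inhibition. The earlier steps shown here either stayed within the scatter or, in the one case beyond it, went towards weaker inhibition, so this position is less indifferent to its substituent than the first three compounds suggested, although the size of the step is still modest. Nothing at hand links this step to a measured property of either group, so the change can be recorded but not explained.

The compounds shown leave open whether this step is particular to nitro or would recur with other groups on the same carbon, such as a nitrile, a carboxylic acid or an amine. They also leave open whether nitro would give a similar step with the 3-methoxyphenyl or 2-(methylsulfanyl)phenyl substitution patterns, and whether the step holds in any other cell line.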